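The source may hold more compounds than are shown below. What is called first, only, known or untested is meant among the compounds shown, and "the series" means these compounds.

The three measured compounds share one core and differ only in the amine at the end of the chain attached to the aromatic oxygen. Compound 1 `COc1cc2c(Oc3ccc(NC(=O)c4nn(-c5ccccc5C(F)(F)F)c(=O)cc4C)cc3F)ccnc2cc1OCCCN1CCCC1` gives 100 nM in a functional assay on MKN-45 cells (Homo sapiens) for inhibition, read by MTT assay, with a stated time of 72 h; on this read-out higher numbers stand for weaker inhibition and lower numbers for stronger inhibition. Compound 2 `COc1cc2c(Oc3ccc(NC(=O)c4nn(-c5ccccc5C(F)(F)F)c(=O)cc4C)cc3F)ccnc2cc1OCCCN1CCCCC1` gives 90 nM in this assay, so that a 1.1-fold lower number from compound 1 to compound 2 (0.05 log units; within the scatter). Compound 3 `COc1cc2c(Oc3ccc(NC(=O)c4nn(-c5ccccc5C(F)(F)F)c(=O)cc4C)cc3F)ccnc2cc1OCCCN1CCN(C)CC1` gives 40 nM in this assay, the lowest of the three numbers: a 2.5-fold lower number from compound 1 to compound 3 (0.40 log units; beyond the scatter), and a 2.3-fold lower number from compound 2 to compound 3 (0.35 log units; beyond the scatter).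

Compound 4 `COc1cc2c(Oc3ccc(NC(=O)c4nn(-c5cccc(F)c5)c(=O)cc4C)cc3F)ccnc2cc1OCCCN1CCN(C)CC1` keeps the 4-methylpiperazin-1-yl end of compound 3 and instead changes the aryl group on the ring nitrogen: 3-fluorophenyl in place of 2-(trifluoromethyl)phenyl on an aromatic nitrogen. None of the three measured steps touches this position; all of them vary the amine only, and the aryl group on the ring nitrogen is the same in compounds 1, 2 and 3. Among the measured compounds shown here, no measured step therefore bears on this change, and there is no basis in the data for expecting a shift in one direction rather than the other.

In the absence of a relevant comparison, compound 4 is expected to stay close to compound 3, with a 1.3-fold higher number from compound 3 to compound 4 (0.10 log units; within the scatter) expected to be no step beyond the scatter. The estimate for compound 4 in this assay is 50 nM, with a range from 15 nM to 200 nM.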

Compound 4, half-maximal inhibitory concentration: 120 nM
For compound 4 the middle estimate is 2.4-fold (0.38 log units) below the measured one; the measured number falls inside the stated range.
By their numbers in this assay, from the lowest: compound 3; then compounds 2, 1 and 4 (each within the scatter of the next).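

The group on the ring nitrogen moves the number in this assay: with 3-fluorophenyl in place of 2-(trifluoromethyl)phenyl there is a 3.0-fold higher number from compound 3 to compound 4 (0.48 log units; beyond the scatter), a modest step but one beyond the scatter. Among the compounds shown here, compounds 1, 2 and 3 varied only the amine at the end of the chain, so this is the first sign that the aryl group on this aromatic nitrogen also counts, and with the 4-methylpiperazin-1-yl end held fixed the 2-(trifluoromethyl)phenyl group gives the stronger inhibition of the two. No measurement at hand offers an explanation for this shift.

The change replaces the substituent and alters where it stands on the phenyl ring in a single step, so the compounds shown do not separate the two, and they leave open how a plain phenyl group, or a phenyl group carrying a methyl group or a nitrile, would read on the same nitrogen. From the compounds shown here alone, it also stays open whether the step would hold with the pyrrolidin-1-yl or piperidin-1-yl ends, as the 3-fluorophenyl group appears here only with the 4-methylpiperazin-1-yl end.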